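Chromene pyridone series: acetyl replacing methoxy

The source may hold more compounds than are shown below. What is called first, only, known or untested is meant among the compounds shown, and "the series" means these compounds.

The series is followed in a functional assay (trachea) with Rattus norvegicus as the target; on this read-out lower numbers stand for lower potency and higher numbers for higher potency (the scale is a negative logarithm). Compound 1 `CC1(C)C=C(n2ccccc2=O)c2ccccc2O1` carries hydrogen on the aromatic carbon in question and gives 5.05. Within the data shown here, compound 2 `COc1ccc2c(c1)C(n1ccccc1=O)=CC(C)(C)O2` carries methoxy on that aromatic carbon and gives 5.99; of the two numbers so far it is the higher, the one measured step, a number 0.94 log units higher from compound 1 to compound 2 (beyond the scatter), lying beyond the scatter. Compound 3 `CC(=O)c1ccc2c(c1)C(n1ccccc1=O)=CC(C)(C)O2` is the next analogue and differs from compound 2 in one place: acetyl in place of methoxy on an aromatic carbon. Among the measured compounds shown here, no measured pair sets acetyl against methoxy, so the only step that bears on this position is a number 0.94 log units higher from compound 1 to compound 2 (beyond the scatter), which shows that a substituent on this aromatic carbon is accompanied by a gain. From the compounds shown here alone, for compound 3 the expectation is therefore a modest further gain, with a wide range since the exchange of methoxy for acetyl itself is untested. The expected step is a number 0.41 log units higher from compound 2 to compound 3 (beyond the scatter), so compound 3 is estimated at 6.4 in this assay, with a range from 5.5 to 7.3.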

Compound 3, logarithm of the reciprocal of the active concentration, log(1/C): 6.65
Compound 3: middle estimate off by 0.25 log units, on the low side; the measured number falls inside the stated range.
By their numbers in this assay, from the lowest: compound 1; then compound 2; then compound 3.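

The exchange of methoxy for acetyl on this aromatic carbon now has a measured size in this assay with a number 0.66 log units higher from compound 2 to compound 3 (beyond the scatter), so the gain at this position does not end with methoxy and the two groups are not equivalent here. Set against hydrogen, acetyl gives a number 1.60 log units higher from compound 1 to compound 3 (beyond the scatter), a larger step than the one seen for methoxy, a number 0.94 log units higher from compound 1 to compound 2 (beyond the scatter), and the order on this carbon among the three groups shown runs hydrogen, then methoxy, then acetyl. Nothing measured alongside these numbers bears on why the groups fall in this order.

With only hydrogen, methoxy and acetyl shown on this carbon, it remains open whether the numbers would rise further or fall back with other groups there, such as a nitrile, an amine, a carboxylic acid or an acyl group with a longer chain. Also open, from the compounds shown here alone, is whether acetyl would keep its gain on another aromatic carbon of the shared core, and whether the same order would hold in any other read-out.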